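The source may hold more compounds than are shown below. What is called first, only, known or untested is meant among the compounds shown, and "the series" means these compounds.

Measured compounds and their values in a functional assay on HL-60 cells (Homo sapiens) for antiproliferative activity, with a stated time of 24 h; a higher number here means a weaker inhibitor, a lower number a stronger inhibitor:

compound 1, `NC(=O)c1c(NC(=O)c2ccccc2Cl)sc2c1CCN(Cc1ccccc1Cl)C2`: 2900 nM
compound 2, `NC(=O)c1c(NC(=O)c2ccccc2Cl)sc2c1CCN(C(=S)Nc1ccccc1)C2`: 5940 nM
compound 3, `CSc1ccccc1NC(=S)N1CCc2c(sc(NC(=O)c3ccccc3Cl)c2C(N)=O)C1`: 14600 nM

Compound 3 stands at the highest number of the three in this assay. Its nearest neighbour is compound 2, from which it differs only by a methylsulfanyl in place of hydrogen, and that step was a 2.5-fold higher number from compound 2 to compound 3 (0.39 log units; beyond the scatter). Compound 1 lies furthest away, since the step of a 5.0-fold higher number from compound 1 to compound 3 (0.70 log units; beyond the scatter) was larger still.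

Compound 4, `NC(=O)c1c(NC(=O)c2ccccc2Cl)sc2c1CCN(C(=S)Nc1c(Cl)cccc1Cl)C2`, is not yet measured. It differs from compound 3 by 2,6-dichlorophenyl in place of 2-(methylsulfanyl)phenyl on an amide-type nitrogen. Within the data shown here, of the measured steps, the one that bears on it most directly is a 2.5-fold higher number from compound 2 to compound 3 (0.39 log units; beyond the scatter), which shows what the methylsulfanyl that now leaves contributed; the two chlorines that enter have no counterpart among the measured compounds. On these data alone, removing the methylsulfanyl alone would be expected to bring the number back toward that of compound 2, while the effect of the two chlorines is unknown. Compound 4 is therefore expected to show a step of a 2.1-fold lower number from compound 3 to compound 4 (0.32 log units; beyond the scatter) in this assay. The estimate for compound 4 is 7000 nM, with a range from 2500 nM to 20000 nM.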

Compound 4, half-maximal inhibitory concentration: 3950 nM
Compound 4: the middle estimate sits 1.8-fold (0.25 log units) above what was measured, and the stated range covers the measured number.
By their numbers in this assay, from the lowest: compounds 1, 4 and 2 (each within the scatter of the next, the first and the last beyond it); then compound 3.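

In this assay, among these compounds, the aryl group on the amide-type nitrogen proved responsive to a change of substituents at constant size: 2,6-dichlorophenyl in place of 2-(methylsulfanyl)phenyl gave (a 3.7-fold lower number from compound 3 to compound 4 (0.57 log units; beyond the scatter)), a larger step than the one that had separated compound 2 from compound 3. The two chlorines, unlike the methylsulfanyl, did not set the compound apart from its plain phenyl counterpart, with (a 1.5-fold lower number from compound 2 to compound 4 (0.18 log units; within the scatter)), so the substituted ring need not cost anything relative to phenyl, and substitution on this ring cannot be read as uniformly unfavourable. Among the compounds shown here, compound 4 is also the only one of the thiocarbonyl-bearing compounds that is not separated from compound 1, with (a 1.4-fold higher number from compound 1 to compound 4 (0.13 log units; within the scatter)), whereas compound 2 and compound 3 both lie beyond the scatter of it.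

The compounds shown leave open whether a single chlorine would read as the two do, and how a methoxy, an amine or a carboxylic acid on this phenyl ring would fare. Nothing available here offers an explanation for why the methylsulfanyl and the two chlorines differ in this way.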